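Trading a nitro group for chlorine on a hydrazone

The compounds below may be only part of what the source reports. "The series", "measured", "known", "first", "only" and "open" are said of these compounds alone.

Three compounds share one core and differ only in the aromatic ring attached to the carbon that carries a double bond to nitrogen. Compound 1 `COc1cc(C(=O)N/N=C/c2c(Cl)cccc2Cl)cc(OC)c1OC` gives 27.8% in a functional assay on BGC-823 cells (Homo sapiens) for antiproliferative activity, read by MTT assay, tested at 5 uM (on this read-out lower numbers stand for a weaker effect and higher numbers for a stronger effect at the one concentration tested), compound 2 `COc1cc(C(=O)N/N=C/c2ccc(F)cc2)cc(OC)c1OC` gives 61.1%, and compound 3 `COc1cc(C(=O)N/N=C/c2ccc(Cl)c([N+](=O)[O-])c2)cc(OC)c1OC` gives 2.3%, the lowest of the three; its nearest neighbour is compound 1, and compound 2 lies furthest from it. Among the compounds with values here, the one measured step, a number 33.3 percentage points higher from compound 1 to compound 2 (beyond the scatter), shows that the substitution pattern of this ring can move the read-out substantially.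

Compound 4 `COc1cc(C(=O)N/N=C/c2ccc(Cl)c(Cl)c2)cc(OC)c1OC` differs from compound 3 by chloro in place of nitro on an aromatic carbon. Within the data shown here, no measured step involves a nitro group, so the measured change from compound 1 to compound 2 bears on it only in showing how much the ring pattern can matter. Given that compound 3 sits at the very bottom of the numbers, the change is expected to raise the read-out, though its size is uncertain. Compound 4 is therefore estimated at 30%, within 5% to 60%, an expected step of a number 27.7 percentage points higher from compound 3 to compound 4 (beyond the scatter).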

Compound 4, a percentage reported as inhibition, at one concentration (the size of the read-out at that concentration, not a potency): 32.7%
For compound 4 the middle estimate is 2.7 percentage points below the measured one, within the range that was stated.
By their numbers in this assay, from the lowest: compound 3; then compounds 1 and 4 (each within the scatter of the next); then compound 2.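

In this assay, chloro in place of nitro on this aromatic carbon gives a number 30.4 percentage points higher from compound 3 to compound 4 (beyond the scatter), so this single change, with the rest of the molecule untouched, is enough to lift compound 4 well clear of compound 3. The arrangement of the two chlorines makes no readable difference here, with a number 4.9 percentage points higher from compound 1 to compound 4 (within the scatter), so the 3,4-dichlorophenyl and 2,6-dichlorophenyl rings cannot be told apart on this read-out. Replacing the 4-fluorophenyl ring with 3,4-dichlorophenyl gives a number 28.4 percentage points lower from compound 2 to compound 4 (beyond the scatter), so this new ring does not reach the level of the fluorinated one. Nothing available explains why these rings differ.

The compounds shown leave open how an amine or a carboxylic acid on this same aromatic carbon would compare with nitro and chloro. They also leave open whether a ring with a single chloro group would match the 3,4-dichlorophenyl ring.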